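The source may hold more compounds than are shown below. What is called first, only, known or untested is meant among the compounds shown, and "the series" means these compounds.

Compound 1 `c1ccc(Nc2ccc3ccccc3n2)nc1` and compound 2 `Cc1ccnc(Nc2ccc3ccccc3n2)c1` share a core, and compound 3 `Oc1ccc(Cl)c2ccc(Nc3ccccn3)nc12` carries a related one; how the core of compound 1 and the core of compound 3 differ is not broken down here. In a functional assay on PC-3 cells (Homo sapiens) for antiproliferative activity, read by MTT assay, with a stated time of 96 h (on this read-out higher numbers stand for weaker inhibition of growth and lower numbers for stronger inhibition of growth), compound 1 reaches only the assay limit of > 30000 nM. In this assay compound 2 gives 26700 nM. The change from compound 1 to compound 2 is methyl in place of hydrogen on an aromatic carbon, and it produced an at least 1.1-fold lower number from compound 1 to compound 2 (0.05 log units; that floor lies within the scatter). That step is only a floor, since compound 1 sits at the limit of > 30000 nM in this assay, at which 1 of the 3 values shown sits. In this assay compound 3 gives 1290 nM, the lowest number among the measured compounds, clearly apart from compound 2. Compound 4 `Cc1ccnc(Nc2ccc3c(Cl)ccc(O)c3n2)c1` carries the same change on the core of compound 3: methyl in place of hydrogen on an aromatic carbon. Because the earlier step of an at least 1.1-fold lower number from compound 1 to compound 2 (0.05 log units; that floor lies within the scatter) was small and its floor lies within the usual scatter, compound 4 is expected to move from compound 3 by about a 1.3-fold lower number from compound 3 to compound 4 (0.11 log units; within the scatter). Compound 4 is therefore estimated at 1000 nM, with a likely range from 400 nM to 3000 nM.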

Compound 4, concentration for 50% growth inhibition: 10200 nM
Estimate against measurement, compound 4: 10-fold (1.01 log units) below; the whole stated range lies below it.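

In this assay, methyl in place of hydrogen on an aromatic carbon of the core of compound 3 weakened growth inhibition, giving a 7.9-fold higher number from compound 3 to compound 4 (0.90 log units; beyond the scatter). Set beside the earlier step, the same change did not carry over from one core to the other, and a small effect on the first core did not foretell the effect on the second: the same change on two cores in this assay, an at least 1.1-fold lower number (0.05 log units; that floor lies within the scatter) from compound 1 to compound 2 and a 7.9-fold higher number (0.90 log units; beyond the scatter) from compound 3 to compound 4, at least 8.8-fold (0.94 log units) apart, beyond the scatter of two such steps. This is a single comparison of two cores, and it does not show what in the cores sets the difference or how the change would behave on any further core.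

The compounds shown leave open whether another group in the same place, such as an ethyl chain, a methoxy group or an amine, would cost as much on the core of compound 3 as methyl does. They also leave open which part of the difference between the core of compound 1 and the core of compound 3 matters, as no pair shown separates those parts.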